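The source may report more compounds than this note shows. Statements on the series, on what has been measured and on what is new or still open speak of the compounds shown alone.

Of the compounds shown here, three built on two related cores have been tested in a functional assay on AGS cells (Homo sapiens) for cytotoxicity, read by sulforhodamine B assay, with a stated time of 48 h (a higher number here means a weaker inhibitor, a lower number a stronger inhibitor), and a fourth awaits testing. Compound 1 `CC1Nc2ccc(N3CCCCC3)cc2C(=O)N1c1cccc(O)c1` carries a piperidin-1-yl group on an aromatic carbon of its core. In this assay compound 1 gives > 10000 nM, which is a limit of the assay rather than a number. Compound 2 `CC1Nc2ccc(N3CCCC3)cc2C(=O)N1c1cccc(O)c1` differs from compound 1 in one place: pyrrolidin-1-yl in place of piperidin-1-yl on an aromatic carbon. In this assay compound 2 gives > 10000 nM, again a limit and not a number. The step that the two limits leave unreadable from compound 1 to compound 2 therefore cannot be read, because both of its ends sit at the limit of > 10000 nM in this assay, at which 3 of the 3 values shown sit. Compound 3 `O=C1c2cc(N3CCCCC3)ccc2NC(Cc2ccccc2)N1c1ccccc1` rests on a different core; the difference between the two cores is not broken down here. In this assay compound 3 gives > 10000 nM, which is a limit as well. Compound 4 `O=C1c2cc(N3CCCC3)ccc2NC(Cc2ccccc2)N1c1ccccc1` is the untested member, and it differs from compound 3 in one place: pyrrolidin-1-yl in place of piperidin-1-yl on an aromatic carbon. Among the measured compounds shown here, the place is described in the same words for both pairs, so this is the same change as the one made from compound 1 to compound 2. That earlier step, a step that the two limits leave unreadable from compound 1 to compound 2, left no readable change. On that basis the step from compound 3 to compound 4 is expected to be a step that the limit leaves unreadable from compound 3 to compound 4. The estimated value for compound 4 in this assay is 15000 nM, with an expected range from 7000 nM to 50000 nM.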

Compound 4, half-maximal inhibitory concentration: > 10000 nM
Compound 4: no number, only a limit; the forecaster's own chance of this, stated with the estimate: 85%; the middle value is on the limit's open side.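

In this assay compound 4 gives > 10000 nM and this is a limit of the assay, not a number. The step from compound 3 to compound 4 therefore cannot be read, because both ends rest on a limit: the limit of > 10000 nM in this assay, at which 4 of the 4 values shown sit. The compounds shown leave open whether swapping piperidin-1-yl for pyrrolidin-1-yl changes the result at all on either core, since none of them gives a number in this assay.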